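The source may report more compounds than this note shows. Statements on the series, on what has been measured and on what is new or still open speak of the compounds shown alone.

Measured so far in a functional assay on RS4-11 cells (Homo sapiens) for inhibition, read by CCK-8 assay, with a stated time of 48 h; on this read-out lower numbers stand for stronger inhibition and higher numbers for weaker inhibition:
- Compound 1 `COc1ccc(S(=O)(=O)Oc2ccccc2/C=C(\C#N)C(=O)Nc2nnc(-c3cccs3)s2)cc1` gives 4750 nM
- Compound 2 `COc1ccc(S(=O)(=O)Oc2ccccc2/C=C(\C#N)C(=O)Nc2nnc(Cc3cccc4ccccc34)s2)cc1` gives 1360 nM
- Compound 3 `COc1ccc(S(=O)(=O)Oc2ccccc2/C=C(\C#N)C(=O)Nc2nnc(Cc3ccccc3)s2)cc1` gives 1060 nM

Compound 3 sits at the low end of these numbers. It is level with its nearest neighbour (a 1.3-fold lower number from compound 2 to compound 3 (0.11 log units; within the scatter)) and well clear of the compound carrying thiophen-2-yl (a 4.5-fold lower number from compound 1 to compound 3 (0.65 log units; beyond the scatter)).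

The next compound is compound 4 `COc1ccc(S(=O)(=O)Oc2ccccc2/C=C(\C#N)C(=O)Nc2nnc(Cc3cccc(F)c3)s2)cc1`, which differs from compound 3 in one place (fluoro in place of hydrogen on an aromatic carbon). It has fluoro in place of hydrogen on an aromatic carbon, so benzyl becomes 3-fluorobenzyl. Among the compounds with values here, no measured step tests a fluoro group, so the evidence is only indirect. Replacing thiophen-2-yl with a whole new group moved the number only modestly (a 3.5-fold lower number from compound 1 to compound 2 (0.54 log units; beyond the scatter)). Exchanging naphthalen-1-yl for phenyl on the saturated chain carbon stayed within the scatter (a 1.3-fold lower number from compound 2 to compound 3 (0.11 log units; within the scatter)). A single fluoro is a much smaller change than either, and the data give no firm direction for it. The expected outcome is therefore no step beyond the scatter (a 1.1-fold lower number from compound 3 to compound 4 (0.05 log units; within the scatter)). For compound 4 the estimated value is 950 nM, with 450 nM to 2000 nM as the expected range.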

Compound 4, half-maximal inhibitory concentration: 1210 nM
Compound 4: middle estimate off by 1.3-fold (0.11 log units), on the low side; the range from low to high includes it.
By their numbers in this assay, from the lowest: compounds 3, 4 and 2 (each within the scatter of the next); then compound 1.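

In this assay, adding a fluoro group on an aromatic carbon of the six-membered ring, meta to a large group, turns benzyl into 3-fluorobenzyl and leaves the number level (a 1.1-fold higher number from compound 3 to compound 4 (0.06 log units; within the scatter)), so this position tolerates this small change without a measurable shift in the cell result. The 3-fluorobenzyl compound is also level with the compound carrying the much larger naphthalen-1-yl group (a 1.1-fold lower number from compound 2 to compound 4 (0.05 log units; within the scatter)), while it remains clearly apart from the thiophen-2-yl compound (a 3.9-fold lower number from compound 1 to compound 4 (0.59 log units; beyond the scatter)); compounds 2, 3 and 4 therefore form one level set, and only compound 1 stands apart from them with a higher number. Nothing measured here bears on what lies behind this flat result.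

Still open, on these data alone, is whether a different group at this same place, such as a methoxy group, an amine or a carboxylic acid, would also leave the number level or would move it beyond the scatter. Also open, as far as these compounds go, is what a longer chain in place of the benzyl link to the core would do to the number.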